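A few compounds are considered here, and "the series" means these few. Any claim that something is new, unique, unknown or untested is made for them only; others in the source may bear on it.

Measured in a functional assay on A2780 cells (Homo sapiens) for antiproliferative activity, read by MTT assay, with a stated time of 48 h; on this read-out lower numbers stand for stronger inhibition and higher numbers for weaker inhibition:
- compound 1 `CO/C=C(\C=C\c1ccc(OC)c(O)c1)c1cc(OC)c(OC)c(OC)c1`: 2220 nM
- compound 2 `C=C(/C=C/c1ccc(OC)c(N)c1)c1cc(OC)c(OC)c(OC)c1`: 582 nM
- compound 3 `CC=C(/C=C/c1ccc(OC)c(N)c1)c1cc(OC)c(OC)c(OC)c1`: 137 nM

Of these three, compound 3 has the lowest number, 137 nM, and its gap to each of the other two lies beyond the scatter. The next compound to be tested in this assay is compound 4 `CCC=C(/C=C/c1ccc(OC)c(N)c1)c1cc(OC)c(OC)c(OC)c1`, which differs from compound 3 in one place: methyl in place of hydrogen on a saturated chain carbon bound to a double-bonded chain carbon. This puts methyl in place of hydrogen on a saturated chain carbon bound to a double-bonded chain carbon, so that methyl becomes ethyl.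

Within the data shown here, only one measured step bears on this change. It is a 4.2-fold lower number from compound 2 to compound 3 (0.63 log units; beyond the scatter), a modest gain beyond the scatter, and it also put methyl in place of hydrogen, though on a double-bonded chain carbon bound to a double-bonded chain carbon. Compound 1 differs from the others in more than one place and offers no guide. Among the measured compounds shown here, no measured pair tests the saturated chain carbon itself, so the earlier gain cannot simply be carried over, and the direction of any change remains open. The expected result is therefore a small step, most likely within the scatter. The estimated step is a 1.1-fold higher number from compound 3 to compound 4 (0.04 log units; within the scatter). For compound 4 the expected value is 150 nM, with an estimated range from 50 nM to 500 nM.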

Compound 4, half-maximal inhibitory concentration: 248 nM
Compound 4: the middle estimate sits 1.7-fold (0.22 log units) below what was measured; low and high end bracket the measured number.
By their numbers in this assay, from the lowest: compounds 3 and 4 (each within the scatter of the next); then compound 2; then compound 1.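

In this assay, taking methyl to ethyl on a saturated chain carbon bound to a double-bonded chain carbon gives a 1.8-fold higher number from compound 3 to compound 4 (0.26 log units; within the scatter), so this further carbon separates compound 3 and compound 4 by no more than the usual scatter, whereas the first methyl, placed on a double-bonded chain carbon, had given a 4.2-fold lower number from compound 2 to compound 3 (0.63 log units; beyond the scatter). Read from the compound with only hydrogen at that double-bonded chain carbon, ethyl still gives a 2.3-fold lower number from compound 2 to compound 4 (0.37 log units; beyond the scatter), so the gain over compound 2 that methyl showed is also seen with ethyl. No measurement is available here that would explain this result.

The compounds shown leave open whether a longer chain such as propyl, or a branched group such as isopropyl, would stay within the scatter of compound 3 and compound 4 or move away from them. They also leave open what a chain ending in an amine or a carboxylic acid would do at this saturated chain carbon.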